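The source may report more compounds than this note shows. Statements on the series, on what has been measured and on what is new or still open speak of the compounds shown alone.

In a functional assay on SK-BR-3 cells (Homo sapiens) for antiproliferative activity (a higher number here means a weaker inhibitor, a lower number a stronger inhibitor), compound 1 `CC(C)=CCc1cc(C(=O)Nc2cc3ccc(OCCCNCC(C)C)c(C)c3oc2=O)ccc1O` gives 1030 nM and compound 2 `CC(C)=CCc1cc(C(=O)Nc2cc3ccc(OCCCNC4CCCCC4)c(C)c3oc2=O)ccc1O` gives 660 nM, with a 1.6-fold lower number from compound 1 to compound 2 (0.19 log units; within the scatter). Compound 3 `CC(C)=CCc1cc(C(=O)Nc2cc3ccc(OCCCNc4ccccc4)c(C)c3oc2=O)ccc1O` stands at > 50000 nM, which is a limit and not a number.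

Compound 4 `CC(C)=CCc1cc(C(=O)Nc2cc3ccc(OCCCNC(C)(C)c4ccccc4)c(C)c3oc2=O)ccc1O` differs from compound 3 as follows: 1-methyl-1-phenylethyl in place of phenyl on an amine nitrogen. This puts 1-methyl-1-phenylethyl in place of phenyl on an amine nitrogen.

The closest evidence is the pair of steps that introduce phenyl at this place: an at least 48-fold higher number from compound 1 to compound 3 (1.68 log units; beyond the scatter) and an at least 75-fold higher number from compound 2 to compound 3 (1.87 log units; beyond the scatter). Both are large, so a large move to a lower number is expected, towards compound 1 at 1030 nM. Among the measured compounds shown here, the entering group still carries an aromatic ring and has no measured precedent, so the expectation is loose.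

The estimated step is an at least 27-fold lower number from compound 3 to compound 4 (1.44 log units; beyond the scatter). Compound 4 is expected at 1800 nM, within an estimated range of 450 nM to 12000 nM.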

Compound 4, half-maximal inhibitory concentration: 960 nM
Compound 4: middle estimate off by 1.9-fold (0.27 log units), on the high side; the range from low to high includes it.
By their numbers in this assay, from the lowest: compounds 2, 4 and 1 (each within the scatter of the next). At a limit, above all of these: compound 3.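

An aromatic ring on the amine nitrogen does not by itself cost activity in this assay: 1-methyl-1-phenylethyl keeps that ring and gives an at least 52-fold lower number from compound 3 to compound 4 (1.71 log units; beyond the scatter). It also sits level with the non-aromatic groups, with a 1.5-fold higher number from compound 2 to compound 4 (0.16 log units; within the scatter) and a 1.1-fold lower number from compound 1 to compound 4 (0.03 log units; within the scatter). The step from compound 3 rests on a limit and not a number: the limit of > 50000 nM in this assay, at which 1 of the 4 values shown sits.

Going by these compounds, whether benzyl on this nitrogen would track with 1-methyl-1-phenylethyl or with phenyl stays open. So does the outcome for a substituted phenyl or a tertiary amine at this place.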